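From ethenyl amide to carboxyethyl: working notes

This account rests on a few compounds, and the source may have more. Where it says the series, first, only, none or still open, it means among the compounds named here.

Among the measured compounds shown here, in a functional assay on A549 cells (Homo sapiens) for inhibition, read by sulforhodamine B assay, with a stated time of 72 h (a lower number here means a stronger inhibitor of growth, a higher number a weaker inhibitor of growth), compound 3 (`CN(C)C(=O)/C=C/c1ccncc1-c1ccc2ccccc2c1`) gives 5800 nM, the only reading in the set that is a number. Compound 1 (`NNC(=O)CCc1ccncc1-c1ccc2ccccc2c1`) stands at a limit of the assay, > 10000 nM. Compound 2 (`O=C(CCc1ccncc1-c1ccc2ccccc2c1)N1CCOCC1`) also stands at a limit, > 10000 nM.

Compound 4 (`O=C(O)CCc1ccncc1-c1ccc2ccccc2c1`) carries 2-carboxyethyl in place of 2-(dimethylcarbamoyl)ethenyl on an aromatic carbon. The closest measured change at this place is an at least 1.7-fold lower number from compound 1 to compound 3 (0.23 log units; that floor lies within the scatter). The other measured step, a step that the two limits leave unreadable from compound 1 to compound 2, gives no size. Like compound 1, compound 4 has an ethyl chain, so a small move in this assay toward a higher number is expected, with a 2.1-fold higher number from compound 3 to compound 4 (0.32 log units; beyond the scatter) as the estimated step. For compound 4 the estimate is 12000 nM, within a range of 6000 nM to 30000 nM.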

Compound 4, concentration for 50% growth inhibition: > 10000 nM
Compound 4 was reported as a limit (the forecaster's own chance of this, stated with the estimate: 70%); the middle value does not contradict the limit.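

In this assay, 2-carboxyethyl in place of 2-(dimethylcarbamoyl)ethenyl gives an at least 1.7-fold higher number from compound 3 to compound 4 (0.23 log units; that floor lies within the scatter), so this first readable step out of compound 3 sets only a floor and does not separate the two compounds. This change replaces the ethenyl link and the dimethylamide together, and all three compounds with an ethyl link now sit at the limit. The steps from compound 1 and compound 2 to compound 4 cannot be read: the limit of > 10000 nM in this assay, at which 3 of the 4 values shown sit.

Among the compounds shown here, open is whether the ethenyl link or the dimethylamide goes with the one numerical reading. A 2-(dimethylcarbamoyl)ethyl group or a 2-carboxyethenyl group at this position would separate the two.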